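This account rests on a few compounds, and the source may have more. Where it says the series, first, only, none or still open, it means among the compounds named here.

Series notes. For the measured compounds named here, compound 3 `CCCCN(CC)c1cc(C)nc2c1NC(=O)CN2c1ccc(Cl)cc1Cl` gives 3.4 nM in an assay on HEK-293T cells for displacement of a labelled ligand from corticotropin-releasing factor receptor 1 (Homo sapiens), read by scintillation counting, with a stated time of 2 h (a lower number here means a stronger inhibitor, a higher number a weaker inhibitor), and stands second highest of the three numbers measured so far, with compound 1 `CCCCN(CC)c1cc(C)nc2c1NC(=O)CN2c1ccc(C)cc1C` at 3.9 nM nearest and compound 2 `CCCCN(CC)c1cc(C)nc2c1NC(=O)CN2c1ccc(Br)cc1Cl` at 2.7 nM furthest, both within the scatter. Compound 4 `CCCCN(CC)c1cc(C)nc2c1NC(=O)CN2c1ccc(Br)cc1C` is not yet measured; it differs from compound 3 by 4-bromo-2-methylphenyl in place of 2,4-dichlorophenyl on a nitrogen on an aromatic ring in a ring. Going by the values given here, the steps that bear on this are a 1.1-fold lower number from compound 1 to compound 3 (0.06 log units; within the scatter), a 1.4-fold lower number from compound 1 to compound 2 (0.16 log units; within the scatter) and a 1.3-fold higher number from compound 2 to compound 3 (0.10 log units; within the scatter), all within the scatter, so the three aryl patterns tried so far have given indistinguishable numbers. The entering 4-bromo-2-methylphenyl shares a bromo with compound 2 and a methyl with compound 1, and no step beyond the scatter is expected in this assay. The expected step is a 1.1-fold lower number from compound 3 to compound 4 (0.04 log units; within the scatter). Compound 4 is therefore estimated at 3.1 nM, range 1.5 nM to 6.5 nM.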

Compound 4, inhibition constant: 4.4 nM
For compound 4 the middle estimate is 1.4-fold (0.15 log units) below the measured one; the measured number falls inside the stated range.
By their numbers in this assay, from the lowest: compounds 2, 3, 1 and 4 (each within the scatter of the next).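

In this assay, the 4-bromo-2-methylphenyl group stays within the scatter of all three earlier aryl groups on this nitrogen (a 1.3-fold higher number from compound 3 to compound 4 (0.11 log units; within the scatter); a 1.6-fold higher number from compound 2 to compound 4 (0.21 log units; within the scatter); a 1.1-fold higher number from compound 1 to compound 4 (0.05 log units; within the scatter)). For the compounds shown here, the single exchanges of methyl for chloro and bromo for methyl therefore resolve no difference, and the four aryl groups cannot be told apart. Nothing available explains this.

All four aryl groups carry only methyl, chloro or bromo. As far as these compounds go, whether a methoxy group or an amine on this phenyl would move the number beyond the scatter remains open.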